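Swapping the sulfonamide terminus for a diethylamide

This account rests on a few compounds, and the source may have more. Where it says the series, first, only, none or still open, it means among the compounds named here.

Measured so far:
compound 1, `CCN(CC)S(=O)(=O)c1ccc(S(=O)(=O)N2CCC[C@@H](C(=O)N3CCC(F)(F)CC3)C2)cc1`: 16 nM
compound 2, `O=C([C@@H]1CCCN(S(=O)(=O)c2ccc(S(=O)(=O)N3CC[C@@H](O)C3)cc2)C1)N1CCC(F)(F)CC1`: 210 nM

Both compounds share a core and differ only at the group attached to the second sulfonyl sulfur. In a functional assay on MIA PaCa-2 cells (Homo sapiens) for inhibition, read by MTT assay, with a stated time of 7 days (on this read-out higher numbers stand for weaker inhibition and lower numbers for stronger inhibition), compound 1 gives 16 nM, and compound 2 gives 210 nM, which is the highest of the two numbers shown. For the measured compounds named here, the single step between them, a 13-fold higher number from compound 1 to compound 2 (1.12 log units; beyond the scatter), is the only measured step in this set.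

Compound 3, `CCN(CC)C(=O)c1ccc(S(=O)(=O)N2CCC[C@@H](C(=O)N3CCC(F)(F)CC3)C2)cc1`, has not been measured. It differs from compound 2 by diethylcarbamoyl in place of (3-hydroxypyrrolidin-1-yl)sulfonyl on an aromatic carbon. Two things happen at once: the diethylamino pattern that compound 1 carries returns, and the sulfonyl linking it to the ring is replaced by a carbonyl. Going by the values given here, the first part is covered by the step from compound 1 to compound 2 run backwards, which was large; the second part has no measured counterpart here, so its effect is unknown.

Compound 3 is therefore expected to give a lower number than compound 2, with the estimated step of a 4.2-fold lower number from compound 2 to compound 3 (0.62 log units; beyond the scatter). The estimate for compound 3 is 50 nM, in a range from 15 nM to 200 nM.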

Compound 3, half-maximal inhibitory concentration: 70 nM
For compound 3 the middle estimate is 1.4-fold (0.15 log units) below the measured one, within the range that was stated.
By their numbers in this assay, from the lowest: compound 1; then compound 3; then compound 2.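

With the diethylamino end held constant, the sulfonyl that joins it to the ring can now be read on its own: in this assay, replacing diethylsulfamoyl with diethylcarbamoyl gives a 4.4-fold higher number from compound 1 to compound 3 (0.64 log units; beyond the scatter). The link therefore counts at this aromatic carbon, not only the amine at its end, and compound 1 remains the lowest of the three, with both of its steps beyond the scatter. A carbonyl link is still compatible with a lower number than the (3-hydroxypyrrolidin-1-yl)sulfonyl group gives, as diethylcarbamoyl shows with a 3.0-fold lower number from compound 2 to compound 3 (0.48 log units; beyond the scatter), but no evidence is available to explain either step.

The step between compound 2 and compound 3 changes both the link and the amine, so the share of each stays unresolved, and a 3-hydroxypyrrolidin-1-yl group on a carbonyl would be needed to separate them. From the compounds shown here alone, it also remains open how this position would respond to a longer chain such as dipropylamino on either link, or to a carboxylic acid on the same aromatic carbon.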